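The source may hold more compounds than are shown below. What is called first, only, known or untested is meant among the compounds shown, and "the series" means these compounds.

- compound 1 `N#C/C(=C\c1ccccc1OS(=O)(=O)c1ccc(F)cc1)C(=O)Nc1nnc(Cc2cccc3ccccc23)s1` gives 68% here
- compound 2 `Cc1ccc(S(=O)(=O)Oc2ccccc2/C=C(\C#N)C(=O)Nc2nnc(Cc3ccc(F)cc3)s2)cc1` gives 72% here
- compound 3 `N#C/C(=C\c1ccccc1OS(=O)(=O)c1ccc(Cl)cc1)C(=O)Nc1nnc(Cc2ccc(F)cc2)s1` gives 68% here

In a functional assay on RS4-11 cells (Homo sapiens) for inhibition, read by CCK-8 assay, with a stated time of 48 h, tested at 20 uM (on this read-out higher numbers stand for more inhibition of growth at the one concentration tested and lower numbers for less inhibition of growth), compound 3 gives 68% and stands level with compound 1, while compound 2 lies within the scatter of it. Compound 4 `N#C/C(=C\c1ccccc1OS(=O)(=O)c1ccc(F)cc1)C(=O)Nc1nnc(Cc2ccc(F)cc2)s1` differs from compound 3 by fluoro in place of chloro on an aromatic carbon with fluoro in place of chloro on an aromatic carbon, para to a large group. For the measured compounds named here, the one measured step at this carbon is a number 4 percentage points lower from compound 2 to compound 3 (within the scatter) with chloro in place of methyl. Compound 1 already carries the (4-fluorophenyl)sulfonyl group and gives 68% with another group elsewhere. No step beyond the scatter is therefore expected in this assay, and the estimated step is a number 1 percentage points higher from compound 3 to compound 4 (within the scatter) at most a small one. For compound 4 the expected value is 69% within an estimated range of 59% to 79% in all.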

Compound 4, percent growth inhibition at one concentration: 59%
Compound 4: middle estimate off by 10 percentage points, on the high side; low and high end bracket the measured number.
By their numbers in this assay, from the lowest: compounds 4, 1, 3 and 2 (each within the scatter of the next, the first and the last beyond it).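

In this assay this carbon shows its first step beyond the scatter, with fluoro in place of methyl: a number 13 percentage points lower from compound 2 to compound 4 (beyond the scatter). Fluoro in place of chloro gives a number 9 percentage points lower from compound 3 to compound 4 (within the scatter), and 4-fluorophenyl in place of naphthalen-1-yl on the chain gives a number 9 percentage points lower from compound 1 to compound 4 (within the scatter), so neither of these two changes stands out from repeat scatter. Nothing measured here explains the step from methyl to fluoro.

As far as these compounds go, whether a methoxy group or an amine on this carbon would shift growth inhibition further remains open. So does whether the step from methyl to fluoro holds with naphthalen-1-yl on the chain.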